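Series notes: tert-butyl added to compound 1

A few compounds are considered here, and "the series" means these few. Any claim that something is new, unique, unknown or untested is made for them only; others in the source may bear on it.

Compound 1 `Cc1cc(C(=O)O)nn1Cc1cc(Br)ccc1OCc1ccccc1` gives 15.1 nM in a functional assay on CHO-K1 cells for antagonist activity at prostaglandin E2 receptor EP1 subtype (Homo sapiens), read by FLIPR (a higher number here means a weaker inhibitor, a lower number a stronger inhibitor), the lowest of the two numbers at hand. Compound 2 `CC(=O)Nc1cc(C(=O)O)nn1Cc1cc(Br)ccc1OCc1ccccc1` gives only a limit in this assay, < 2000 nM (the limit of < 2000 nM in this assay, at which 1 of the 3 values shown sits). Among the measured compounds shown here, compound 3 `Cc1cccc(COc2ccc(Br)cc2Cn2nc(C(=O)O)cc2C)c1` gives 525 nM; the step of a 35-fold higher number from compound 1 to compound 3 (1.54 log units; beyond the scatter) is the one measured change on the six-membered aromatic ring of carbon only. Compound 4 `Cc1cc(C(=O)O)nn1Cc1cc(Br)ccc1OCc1ccc(C(C)(C)C)cc1` differs from compound 1 by tert-butyl in place of hydrogen on an aromatic carbon. The other measured step, a step that the limit leaves unreadable from compound 1 to compound 2, concerns a different ring and gives no readable size. For the measured compounds named here, because the only guide on this ring is the large loss a 35-fold higher number from compound 1 to compound 3 (1.54 log units; beyond the scatter), a rise in the number is expected for compound 4, with wide uncertainty. Compound 4 is estimated at 120 nM, between 20 nM and 900 nM, an expected step of a 7.9-fold higher number from compound 1 to compound 4 (0.90 log units; beyond the scatter).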

Compound 4, inhibition constant: < 2000 nM
Compound 4 was reported as a limit (the forecaster's own chance of this, stated with the estimate: 10%); the middle value lies beyond the limit too.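

Compound 4 is reported only as a limit, so the step from compound 1 to compound 4 cannot be read: the limit of < 2000 nM in this assay, at which 2 of the 4 values shown sit. The compounds shown leave open the size of the change that tert-butyl in place of hydrogen brings in this assay.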